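Acetamido to propanoylamino on a fluorophenylsulfonyl piperidine

The source may hold more compounds than are shown below. What is called first, only, known or untested is meant among the compounds shown, and "the series" means these compounds.

Measured so far in a functional assay on the whole organism with Mus musculus as the target, with a stated time of 30 min; a lower number here means that less compound is needed, a higher number that more compound is needed for the effect:
compound 1 `CC(=O)NC1CCN(S(=O)(=O)c2ccc(F)cc2)CC1`, 0.01 mg/kg
compound 2 `CCC(=O)NC1CCCN(S(=O)(=O)c2ccc(F)cc2)C1`, 1 mg/kg
compound 3 `CC(=O)N1CCC(NS(=O)(=O)c2ccc(F)cc2)CC1`, 0.1 mg/kg

Compound 1 has the lowest number of the three, the gap to compound 3 and the larger gap to compound 2 both lying beyond the scatter, so compound 1 needs the least compound for the effect in this assay. Among the measured compounds shown here, no pair among the measured compounds differs in a single place, so no step is computed for them.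

The next compound, compound 4 `CCC(=O)NC1CCN(S(=O)(=O)c2ccc(F)cc2)CC1`, differs from compound 1 by one change: methyl in place of hydrogen on a saturated chain carbon bound to a carbonyl carbon. Compound 2 also carries a propanoyl group, but on a differently arranged core, so its value in this assay says only that such an amide can still give an effect and does not fix the size of this step.

The change is expected to raise the number modestly, and the step of a 3.0-fold higher number from compound 1 to compound 4 (0.48 log units; beyond the scatter) is the estimate, within the scatter or slightly beyond it. For compound 4 a minimum effective dose of 0.03 mg/kg is expected, in the range 0.008 mg/kg to 0.15 mg/kg.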

Compound 4, minimum effective dose: 0.1 mg/kg
Compound 4: middle estimate off by 3.3-fold (0.52 log units), on the low side; low and high end bracket the measured number.
By their numbers in this assay, from the lowest: compound 1; then compounds 3 and 4 (each within the scatter of the next); then compound 2.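

Among the compounds shown here, this is the first single-place comparison: on the shared core, going from acetamido to propanoylamino in this assay gives a 10-fold higher number from compound 1 to compound 4 (1.00 log units; beyond the scatter) and shows that the dose depends on this position. Methyl in place of hydrogen on the saturated chain carbon bound to a carbonyl carbon therefore carries a cost, yet compound 4 still gives an effect at 0.1 mg/kg and the position is not closed to added carbon. No measurement shown bears on why the step has this size.

A single step sets no trend, so a longer chain such as butanoyl, a branched chain such as isobutyryl or an amine on this same carbon could each give a different number. From the compounds shown here alone, whether the same step holds on the core of compound 2 also stays open.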